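Benzyl Out, Fluoro In on a Shared Core

The source may report more compounds than this note shows. Statements on the series, on what has been measured and on what is new or still open speak of the compounds shown alone.

Within the data shown here, compound 1 `N#Cc1ccc(NC(=O)c2cc(Cc3ccccc3)ccc2O)cc1` holds the only full number in a functional assay on KG-1 cells (Homo sapiens) for cytotoxicity, read by luminescence and CellTiter-Glo, with a stated time of 3 days (on this read-out lower numbers stand for stronger inhibition and higher numbers for weaker inhibition), giving 1930 nM. Compound 2 `COc1cccc(C(=O)Nc2ccc(C#N)cc2)c1O` reaches only the limit of this assay, > 10000 nM, which is a limit and not a number (the limit of > 10000 nM in this assay, at which 1 of the 2 values shown sits). Compound 3 `N#Cc1ccc(NC(=O)c2cc(F)ccc2O)cc1` differs from compound 1 in one place: fluoro in place of benzyl on an aromatic carbon, with the benzyl leaving and a fluoro entering. Among the measured compounds shown here, no measured pair shows a step of this kind, so the step from compound 1 to compound 3 is expected to weaken inhibition beyond the usual scatter, a 3.1-fold higher number from compound 1 to compound 3 (0.49 log units; beyond the scatter). Compound 3 is estimated at 6000 nM, within 1800 nM to 20000 nM.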

Compound 3, half-maximal inhibitory concentration: 2670 nM
Compound 3: middle estimate off by 2.2-fold (0.35 log units), on the high side, within the range that was stated.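

In this assay, fluoro in place of benzyl on the aromatic carbon para to a hydroxy group gives a 1.4-fold higher number from compound 1 to compound 3 (0.14 log units; within the scatter). The benzyl, with its 7 heavy atoms and its ring, can therefore be replaced by a single fluorine at this position without a change that stands out from the scatter. Nothing shown here explains why the two groups read alike.

On these data alone, only these two groups are compared at this position, so it remains open whether an amine, a carboxylic acid or a longer chain there would shift the number.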